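The compounds below may be only part of what the source reports. "The series", "measured", "known", "first", "only" and "open" are said of these compounds alone.

Measured so far: compound 1 `CCOC(=O)c1cccc(-c2ccc(CN(C)C)cc2)c1` with 150000 nM, compound 2 `CCOC(=O)c1cccc(-c2ccc(C(C)N(C)C)cc2)c1` with 200000 nM, and compound 3 `COC(=O)Nc1cccc(-c2ccc(N(C)C)cc2)c1` with 5000 nM, all in an assay on COS-7 cells for inhibition of patatin-like phospholipase domain-containing protein 2 (Mus musculus); a lower number here means a stronger inhibitor, a higher number a weaker inhibitor.

Compound 3 stands lowest of the three; its difference from the core of compound 1 is not broken down here. Within the first core, compound 2 differs from compound 1 by methyl in place of hydrogen on a saturated chain carbon bound to an amine nitrogen and an aromatic carbon, a change that made a 1.3-fold higher number from compound 1 to compound 2 (0.12 log units; within the scatter).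

Compound 4 `CCOC(=O)Nc1cccc(-c2ccc(N(C)C)cc2)c1` has not yet been measured. It differs from compound 3 by methyl in place of hydrogen on a saturated chain carbon bound to an oxygen next to a carbonyl group. This is the same kind of change as before, but around a different place: there the carbon was bound to an amine nitrogen and an aromatic carbon, here it is bound to an oxygen next to a carbonyl group. Because the earlier step of a 1.3-fold higher number from compound 1 to compound 2 (0.12 log units; within the scatter) stayed within the scatter, a step of similar size is expected here, no change at the digits printed from compound 3 to compound 4 (within the scatter), in this assay. Compound 4 is therefore estimated at 5000 nM, between 2000 nM and 12000 nM.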

Compound 4, half-maximal inhibitory concentration: 3000 nM
Estimate against measurement, compound 4: 1.7-fold (0.22 log units) above; low and high end bracket the measured number.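

In this assay the swap of hydrogen for methyl on the saturated chain carbon bound to an oxygen next to a carbonyl group gave a 1.7-fold lower number from compound 3 to compound 4 (0.22 log units; within the scatter) on this core. Set beside the same kind of change on the core of compound 1, the two steps cannot be told apart: the same change on two cores in this assay, a 1.3-fold higher number (0.12 log units; within the scatter) from compound 1 to compound 2 and a 1.7-fold lower number (0.22 log units; within the scatter) from compound 3 to compound 4, 2.2-fold (0.35 log units) apart, within the scatter of two such steps. So the added methyl left the number within the scatter on both cores, but two pairs, with the methyl at different places, do not show that this would hold on any other core or explain why it holds here.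

The compounds shown leave open whether a longer chain, such as propyl or butyl, in place of the ethyl of compound 4 would keep the number where it stands. They also leave open what an amine or a carboxylic acid at the end of that chain would do.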